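Carboxymethoxy to hydroxy: notes on a series at its limit

The source may hold more compounds than are shown below. What is called first, only, known or untested is meant among the compounds shown, and "the series" means these compounds.

Measured in an ADME assay on BJ cells (Homo sapiens) for cytotoxicity, with a stated time of 72 h; on this read-out higher numbers stand for an effect only at larger amounts of compound and lower numbers for an effect already at smaller amounts:
- compound 1 `O=C(Nc1ccc(F)c(-c2nc3ccccc3o2)c1)c1cc([N+](=O)[O-])ccc1Cl`: > 25000 nM
- compound 2 `O=C(O)COc1cc(Cl)c(C(=O)Nc2cccc(-c3nc4ccccc4s3)c2)cc1[N+](=O)[O-]`: > 25000 nM
- compound 3 `Cc1ccc(-c2nc3ccccc3s2)cc1NC(=O)c1cc([N+](=O)[O-])c(N2CCC(C(=O)O)CC2)cc1Cl`: > 25000 nM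

Compound 2 gives > 25000 nM, which is a limit of the assay and not a number. The whole set reads the same way: the limit of > 25000 nM in this assay, at which 3 of the 3 values shown sit. Among the measured compounds shown here, compound 2 therefore has no rank among the three, and no step between measured compounds can be read.

Compound 4 `O=C(Nc1cccc(-c2nc3ccccc3s2)c1)c1cc([N+](=O)[O-])c(O)cc1Cl` differs from compound 2 in one place, carboxymethoxy to hydroxy: hydrogen in place of carboxymethyl on an oxygen on an aromatic ring. This puts hydrogen in place of carboxymethyl on an oxygen on an aromatic ring.

No step beyond the scatter is expected in this assay, in either direction. The expected change is a number no higher from compound 2 to compound 4 (the limit leaves the size open). This expectation rests partly on compound 1, which carries no carboxymethyl and still gives > 25000 nM, also a limit. For compound 4 the estimated value is 25000 nM, within an expected range of 10000 nM to 50000 nM.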

Compound 4, half-maximal effective concentration: > 25000 nM
Compound 4: a limit, no number (the forecaster's own chance of this, stated with the estimate: 80%); the middle value sits exactly at the limit.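

No step for carboxymethoxy to hydroxy can be read between compound 2 and compound 4, because both values are limits and not numbers: the limit of > 25000 nM in this assay, at which 4 of the 4 values shown sit.

The compounds shown leave open at what concentration any of them would reach a half-maximal effect, and whether carboxymethoxy to hydroxy shifts that concentration at all.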